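The source may report more compounds than this note shows. Statements on the series, on what has been measured and on what is new or still open speak of the compounds shown alone.

Measured so far in an assay on HEK293 cells for negative allosteric modulation of metabotropic glutamate receptor 5 (Homo sapiens), read by FLIPR, with a stated time of 1 h; on this read-out lower numbers stand for stronger inhibition and higher numbers for weaker inhibition:
compound 1 `O=C(C1CCC(F)(F)CC1)N1CCc2nc(C#Cc3ccccc3)sc2C1`: > 10000 nM, a limit of the assay
compound 2 `CC1CCCC(C(=O)N2CCc3nc(C#Cc4ccccc4)sc3C2)C1`: > 10000 nM, a limit of the assay

Compound 2 therefore stands only at a limit in this assay, with no number behind it. Among the compounds with values here, the one step measured between these two, a step that the two limits leave unreadable from compound 1 to compound 2, cannot be read because the limit of > 10000 nM in this assay, at which 2 of the 2 values shown sit, covers both ends of it. Nothing in the measured pair shows whether changing the ring on the carbonyl carbon moves the read-out at all.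

Compound 3 `O=C(N1CCC(F)CC1)N1CCc2nc(C#Cc3ccccc3)sc2C1` has not been measured. It differs from compound 2 in one place: 4-fluoropiperidin-1-yl in place of 3-methylcyclohexyl on a carbonyl carbon. Within the data shown here, the only measured step that bears on this change is the step from compound 1 to compound 2, and its size is not readable, so it gives no direction and no size to carry over. Both measured compounds sit at the same limit, and the change to compound 3 is of the same kind, a different ring on the carbonyl carbon.

The step from compound 2 to compound 3 is therefore expected to be a number no higher from compound 2 to compound 3 (the limit leaves the size open), with no readable direction. Compound 3 is estimated in this assay at 10000 nM, with a range from 2500 nM to 40000 nM, and most likely again only a limit will be reported.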

Compound 3, half-maximal inhibitory concentration: > 10000 nM
Compound 3 gave a limit, no number; the forecaster's own chance of this, stated with the estimate: 75%; the middle value lies on the limit itself.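

Compound 3 gives > 10000 nM in this assay, again a limit and not a number. No new step can be read from compound 3 to compound 1 or compound 2, because all three sit at one limit: the limit of > 10000 nM in this assay, at which 3 of the 3 values shown sit. The compounds shown leave open whether any of these rings on the carbonyl carbon changes the read-out at all.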